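A few compounds are considered here, and "the series" means these few. Any claim that something is new, unique, unknown or untested is made for them only; others in the source may bear on it.

Compounds measured so far:
- compound 1 `Cc1nc(S(C)(=O)=O)ccc1Oc1ncnc(OC2CCN(C(=O)OC(C)C)CC2)c1F`: 77%
- compound 2 `Cc1nc(S(C)(=O)=O)ccc1Oc1ncnc(OC2CCN(C(=O)O[C@H](C)CF)CC2)c1F`: 79%

In a functional assay on isolated protein for inhibition of Glucose-dependent insulinotropic receptor (Rattus norvegicus), read by HTRF and cAMP accumulation (on this read-out higher numbers stand for larger maximal responses and lower numbers for smaller maximal responses), compound 1 gives 77% and compound 2 gives 79%. Compound 2 holds the higher of the two numbers, but the gap to compound 1 is small: a number 2 percentage points higher from compound 1 to compound 2 (within the scatter). The two values therefore cannot be told apart.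

Compound 3 `Cc1nc(S(C)(=O)=O)ccc1Oc1ncnc(OC2CCN(C(=O)O[C@H](C)C(F)(F)F)CC2)c1F` has not yet been measured. It differs from compound 2 in one place: trifluoromethyl in place of fluoromethyl on a saturated chain carbon bound to an oxygen next to a carbonyl group and a saturated chain carbon. Going by the values given here, the only measured step that touches this region of the molecule is a number 2 percentage points higher from compound 1 to compound 2 (within the scatter), which added fluorine at the same part of the chain and moved the maximal response by almost nothing. One step of that kind is thin ground, and the change to compound 3 is larger than the one already seen. Still, nothing measured suggests any direction beyond the scatter in this assay, so the expectation is a step close to zero: a number 1 percentage points lower from compound 2 to compound 3 (within the scatter). Compound 3 is estimated at 78%, with a range from 65% to 90%.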

Compound 3, largest response reached (reported as efficacy), in percent of the reference or control that the assay uses: 85%
Beside the measured number, compound 3's estimate is 7 percentage points below it; the range from low to high includes it.
By their numbers in this assay, from the lowest: compounds 1, 2 and 3 (each within the scatter of the next).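

In this assay, the fully fluorinated end of the chain is tolerated at this position: a number 6 percentage points higher from compound 2 to compound 3 (within the scatter), and against the unfluorinated isopropyl group, a number 8 percentage points higher from compound 1 to compound 3 (within the scatter). Both steps stay within the scatter, so the three fluorine atoms of the 1-(trifluoromethyl)ethyl group do not separate compound 3 from compound 1 or compound 2, and the maximal response stays in the same band across the isopropyl, 1-(fluoromethyl)ethyl and 1-(trifluoromethyl)ethyl groups. No supporting data on the origin of these numbers are at hand.

The compounds shown leave open whether this tolerance extends to a longer chain, such as a 1-(trifluoromethyl)propyl group, or to a cyclopropyl ring on the same oxygen. They also do not show how an amine or a carboxylic acid at the end of this chain would read in this assay.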